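Hydrazone chain extension on a methoxyphenyl thiazole core

The compounds below may be only part of what the source reports. "The series", "measured", "known", "first", "only" and "open" are said of these compounds alone.

Working notes on a small hydrazone series sharing one core. Compound 1 `COc1cccc(-c2csc(NN=C(C)C)n2)c1` is the acetone-derived hydrazone; in an assay on isolated protein for inhibition of Amine oxidase [flavin-containing] A (Homo sapiens), read by fluorescence (on this read-out lower numbers stand for stronger inhibition and higher numbers for weaker inhibition), compound 1 gives 4430 nM. Compound 2 `COc1cccc(-c2csc(N/N=C/c3cccc4ccccc34)n2)c1` carries a naphthyl-derived hydrazone instead, and in this assay compound 2 gives 3640 nM. The two numbers lie within the scatter of each other, so compound 1 is not separated from compound 2 on the data shown, and neither can be called the more potent.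

Compound 3 `CCC/C(C)=N/Nc1nc(-c2cccc(OC)c2)cs1` is the unmeasured neighbour of compound 1. The difference is ethyl in place of hydrogen on a saturated chain carbon bound to a carbon with a double bond to nitrogen. Going by the values given here, no measured pair shows what such a step does. The expectation is a step of a 1.4-fold lower number from compound 1 to compound 3 (0.14 log units; within the scatter) that stays within or barely beyond the scatter, leaning slightly toward a lower number. Compound 3 is therefore estimated at 3200 nM, with a range from 1200 nM to 8500 nM.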

Compound 3, half-maximal inhibitory concentration: 1310 nM
The estimate for compound 3 lay 2.4-fold (0.39 log units) above the measured number, within the range that was stated.
By their numbers in this assay, from the lowest: compound 3; then compounds 2 and 1 (each within the scatter of the next).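

In this assay, going by these compounds alone, ethyl in place of hydrogen on a saturated chain carbon bound to a carbon with a double bond to nitrogen gives a 3.4-fold lower number from compound 1 to compound 3 (0.53 log units; beyond the scatter) and so moves the number beyond the scatter, whereas the earlier compounds offered no step at this position. This shows that the position responds to added chain carbons, though the step is modest and rests on a single pair. Nothing on hand bears on why the number falls with this change.

On these data alone, whether a longer chain such as butyl at this carbon would extend the step or reverse it stays open, as does the effect of a chain ending in an amine or a carboxylic acid. A single step also cannot show whether the number follows chain length, so methyl at this carbon remains an open comparison.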